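Flavone amine side chains: pyrrolidine against methylpiperazine

The source may report more compounds than this note shows. Statements on the series, on what has been measured and on what is new or still open speak of the compounds shown alone.

For the measured compounds named here, compound 3 `COc1cc2oc(-c3ccccc3)cc(=O)c2c(O)c1OCCCCN1CCCC1` stands lowest of the three numbers so far, with 10600 nM in a functional assay on BCG823 cells (Homo sapiens) for antiproliferative activity, read by MTT assay, with a stated time of 48 h; a lower number here means a stronger inhibitor, a higher number a weaker inhibitor; its nearest neighbour is compound 1 `CN1CCN(CCCCOc2c(O)cc3oc(-c4ccccc4)cc(=O)c3c2O)CC1` at 82900 nM, and compound 2 `O=c1cc(-c2ccccc2)oc2cc(O)c(OCCCCN3CCCC3)c(O)c12` gives 86400 nM. The methyl for hydrogen change gave an 8.2-fold lower number from compound 2 to compound 3 (0.91 log units; beyond the scatter). Compound 4 `COc1cc2oc(-c3ccccc3)cc(=O)c2c(O)c1OCCCCN1CCN(C)CC1` differs from compound 3 by 4-methylpiperazin-1-yl in place of pyrrolidin-1-yl on a saturated chain carbon, four bonds along the chain from an oxygen on an aromatic ring. Going by the values given here, the one measured step bearing on this change is the reverse swap, which gave a 1.0-fold higher number from compound 1 to compound 2 (0.02 log units; within the scatter). Among the compounds with values here, no other pair speaks to the amine. The expectation for compound 4 is therefore no step beyond the scatter, and the expected step reads a 1.0-fold higher number from compound 3 to compound 4 (0.02 log units; within the scatter). Compound 4 is estimated at 11000 nM, within a range of 4500 nM to 27000 nM.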

Compound 4, half-maximal inhibitory concentration: 53500 nM
Compound 4: the middle estimate sits 4.9-fold (0.69 log units) below what was measured; measured number outside the range, above it.
By their numbers in this assay, from the lowest: compound 3; then compounds 4, 1 and 2 (each within the scatter of the next).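

In this assay the amine swap turns out to depend on the core, giving a 5.0-fold higher number from compound 3 to compound 4 (0.70 log units; beyond the scatter) where the oxygen on the aromatic ring carries methyl, unlike the flat step seen where it carries hydrogen: the same change on two cores in this assay, a 1.0-fold higher number (0.02 log units; within the scatter) from compound 1 to compound 2 and a 5.0-fold lower number (0.70 log units; beyond the scatter) from compound 4 to compound 3, 5.3-fold (0.72 log units) apart, beyond the scatter of two such steps.
The methyl for hydrogen change depends on the amine in turn, giving only a 1.5-fold lower number from compound 1 to compound 4 (0.19 log units; within the scatter) with 4-methylpiperazin-1-yl on the chain, a smaller step than with pyrrolidin-1-yl: the same change on two cores in this assay, an 8.2-fold lower number (0.91 log units; beyond the scatter) from compound 2 to compound 3 and a 1.5-fold lower number (0.19 log units; within the scatter) from compound 1 to compound 4, 5.3-fold (0.72 log units) apart, beyond the scatter of two such steps.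

From the compounds shown here alone, whether this dependence extends to other amines, such as morpholin-4-yl or dimethylamino, stays open.
So does its behaviour on a shorter chain, such as 3-(pyrrolidin-1-yl)propyl.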